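Ring-Closed Amine Variant Among Three Measured Compounds

The source may report more compounds than this note shows. Statements on the series, on what has been measured and on what is new or still open speak of the compounds shown alone.

Compound 1, `CN(C)/C=N/c1c(C=O)c(-c2ccccc2)nn1-c1cccc(Cl)c1`: 6900 nM
Compound 2, `COc1ccc(-c2nn(-c3ccccc3)c(/N=C/N(C)C)c2C=O)cc1`: 9900 nM
Compound 3, `CCN(/C=N/c1c(C=O)c(-c2ccccc2)nn1-c1ccccc1)CC`: 28800 nM

These three compounds were measured in a functional assay on NCI-H661 cells (Homo sapiens) for inhibition, read by MTT assay, with a stated time of 72 h; on this read-out higher numbers stand for weaker inhibition of growth and lower numbers for stronger inhibition of growth. Compound 3 gives 28800 nM, the highest number of the three, and so the weakest inhibition of growth among them. Its nearest neighbour is compound 2 with 9900 nM, and the gap between the two lies beyond the usual scatter. Compound 1, at 6900 nM, stands furthest from compound 3, again beyond the scatter. The three differ from one another in more than one place, so no single change among them can be isolated.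

Compound 4, `O=Cc1c(-c2ccccc2)nn(-c2ccccc2)c1/N=C/N1CCCCC1`, is built from compound 3 by one change: piperidin-1-yl in place of diethylamino on a carbon with a double bond to nitrogen. Among the compounds with values here, no measured pair shows this change, so its effect must be anticipated rather than read off. Within the data shown here, the two groups are close relatives, an open chain of carbons on the nitrogen against a ring of the same kind of atoms, and nothing among the measured compounds points to a large effect of such a swap. The expected step of a 1.4-fold lower number from compound 3 to compound 4 (0.16 log units; within the scatter) is therefore small, if anything toward a lower number, and may well lie within the scatter. Compound 4 is estimated at 20000 nM, with a range from 7000 nM to 60000 nM.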

Compound 4, concentration for 50% growth inhibition: 17700 nM
For compound 4 the middle estimate is 1.1-fold (0.05 log units) above the measured one; the measured number falls inside the stated range.
By their numbers in this assay, from the lowest: compounds 1, 2, 4 and 3 (each within the scatter of the next, the first and the last beyond it).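

In this assay, piperidin-1-yl in place of diethylamino on a carbon with a double bond to nitrogen gives a 1.6-fold lower number from compound 3 to compound 4 (0.21 log units; within the scatter). Within the data shown here, this is the first pair here that differs in one place, and it shows that at this position an open pair of ethyl chains and a six-membered ring cannot be told apart beyond the usual scatter of repeated measurements, so neither of the two compounds can be ranked above the other. Nothing at hand offers an explanation for the size of this step, so the result stands as a bare observation.

What the compounds shown leave open is how other amines behave at this place, such as a morpholin-4-yl or pyrrolidin-1-yl ring, or a longer chain such as dipropylamino, each of which would need a number of its own. Also open, as far as these compounds go, is whether the same swap would give a step of similar size in the presence of the chloro group of compound 1 or the methoxy group of compound 2.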